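Trifluoromethyl in place of fluoro in compound 3

This account rests on a few compounds, and the source may have more. Where it says the series, first, only, none or still open, it means among the compounds named here.

In a functional assay on MGC-803 cells (Homo sapiens) for antiproliferative activity, read by MTT assay, with a stated time of 48 h (on this read-out lower numbers stand for an effect already at smaller amounts and higher numbers for an effect only at larger amounts of compound), compound 1 `CC1=NN(S(=O)(=O)c2ccc([N+](=O)[O-])cc2)C(c2cc(Br)ccc2O)C1` gives 22200 nM and compound 2 `CC1=NN(S(=O)(=O)c2ccc(F)cc2)C(c2cc(Br)ccc2O)C1` gives 15500 nM as its number, so these two lie within the scatter of each other and neither ranks ahead. Going by the values given here, the only measured step of a similar kind, fluoro in place of nitro on an aromatic carbon, is a 1.4-fold lower number from compound 1 to compound 2 (0.16 log units; within the scatter) and stays small. Compound 3 `CC1=NN(S(=O)(=O)c2ccc(C(F)(F)F)cc2)C(c2cc(Br)ccc2O)C1` brings trifluoromethyl in place of fluoro on an aromatic carbon as one further exchange: trifluoromethyl in place of fluoro on an aromatic carbon, para to a large group. With only a 1.4-fold lower number from compound 1 to compound 2 (0.16 log units; within the scatter) as a guide, no step beyond the scatter is expected in this assay for this change, although a single step is thin evidence. The expected step is a 1.0-fold higher number from compound 2 to compound 3 (0.01 log units; within the scatter) at this estimate. Compound 3 is expected at 16000 nM with an estimated range from 8000 nM to 32000 nM on this read-out.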

Compound 3, half-maximal effective concentration: 30000 nM
Compound 3: middle estimate off by 1.9-fold (0.27 log units), on the low side, within the range that was stated.
By their numbers in this assay, from the lowest: compounds 2, 1 and 3 (each within the scatter of the next).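

With trifluoromethyl on the aromatic carbon para to a large group, this assay gives a 1.9-fold higher number from compound 2 to compound 3 (0.29 log units; within the scatter) and a 1.4-fold higher number from compound 1 to compound 3 (0.13 log units; within the scatter) as its steps, so fluoro, nitro and trifluoromethyl all stay within the scatter of one another at this place. The earlier pair covered only fluoro and nitro; this third group, with more heavy atoms than fluoro and no hydrogen-bond donor or acceptor, still brings no separation, so this position does not yet tell these groups apart on this read-out. Nothing available on these compounds speaks to why the groups fall so close together.

From the compounds shown here alone, whether an amine, a carboxylic acid or a longer chain at this place would give a step beyond the scatter stays open. The three compounds also share the rest of the core, so they say nothing about changes elsewhere.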